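The source may report more compounds than this note shows. Statements on the series, on what has been measured and on what is new or still open speak of the compounds shown alone.

Measured compounds:
Compound 1 `O=C(Nc1ccc(F)cc1)c1cc(=O)[nH]c2cc(Br)ccc12` — in a functional assay on KYSE-70 cells for antiproliferative activity against KYSE-70 cell line (Homo sapiens), read by MTT assay, with a stated time of 72 h (a lower number here means a stronger inhibitor, a higher number a weaker inhibitor), compound 1 reaches only the limit of the assay, > 20000 nM.
Compound 2 `O=C(Nc1cc(F)ccc1F)c1cc(=O)[nH]c2cc(Br)ccc12` — in this assay compound 2 likewise gives a limit and no number, > 20000 nM.
Compound 3 `O=C(Nc1cccc(F)c1)c1cc(=O)[nH]c2cc(-c3ccc(F)cc3)ccc12` — in this assay compound 3 gives a measured value of 3300 nM.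

For the measured compounds named here, compound 3 therefore stands as the only member of the set with an actual number; the other two sit at the limit of > 20000 nM in this assay, at which 2 of the 3 values shown sit, which says nothing beyond the ceiling of the assay. Going by the values given here, no two measured compounds differ in just one place, so no measured step is available to lean on.

Compound 4 `O=C(Nc1cccc(F)c1)c1cc(=O)[nH]c2cc(-c3ccc(F)nc3)ccc12` differs from compound 3 by 6-fluoropyridin-3-yl in place of 4-fluorophenyl on an aromatic carbon. Among the compounds with values here, since no comparable step has been measured here, the step of a 1.1-fold lower number from compound 3 to compound 4 (0.04 log units; within the scatter) is expected to be small, in either direction, and likely not beyond the usual scatter of repeated runs. On that basis compound 4 is estimated at 3000 nM, with a plausible range from 1200 nM to 8000 nM.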

Compound 4, half-maximal inhibitory concentration: > 20000 nM
Compound 4 gave a limit, no number (the forecaster's own chance of this, stated with the estimate: 10%); at least 6.6-fold (0.82 log units) between middle value and limit.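

For the compounds shown here, the change on this aromatic carbon is the first measured step in the set, and it is not neutral: in this assay, 6-fluoropyridin-3-yl in place of 4-fluorophenyl gives an at least 6.0-fold higher number from compound 3 to compound 4 (0.78 log units; beyond the scatter). Activity here therefore depends on more than a fluorinated six-membered aromatic ring at this position, since replacing a single ring carbon with nitrogen is enough to produce this step. Compound 3 remains the only compound with an actual number, so the size of the step has a lower bound but no upper one: the limit of > 20000 nM in this assay, at which 3 of the 4 values shown sit.

The compounds shown leave open how far compound 4 lies from compound 3. They also leave open whether a pyridin-3-yl without the fluorine, or a phenyl ring carrying an amine or a carboxylic acid, would hold the activity of compound 3 at this position.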